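This account rests on a few compounds, and the source may have more. Where it says the series, first, only, none or still open, it means among the compounds named here.

Compound 3 `Cn1cncc1CN1CC(N(Cc2ccc(S(C)(=O)=O)cc2)S(=O)(=O)c2ccccn2)Cc2cc(C#N)ccc21` stands second highest of three numbers in an ADME assay on Caco-2 cells (Homo sapiens) for permeability, in the apical to basolateral direction (on this read-out lower numbers stand for lower permeability and higher numbers for higher permeability), where compound 3 gives 0.2 10^-6 cm/s. Compound 1 `Cn1cncc1CN1CC(N(CCn2cccc2)S(=O)(=O)c2ccccn2)Cc2cc(C#N)ccc21` gives 12.4 10^-6 cm/s, and compound 2 `Cn1cnc(S(=O)(=O)N2CCC(CN(C3Cc4cc(C#N)ccc4N(Cc4cncn4C)C3)S(=O)(=O)c3ccccn3)CC2)c1` gives 0.1 10^-6 cm/s, a value within the scatter of compound 3. Compound 4 `CC(C)OC(=O)N1CCC(CN(C2Cc3cc(C#N)ccc3N(Cc3cncn3C)C2)S(=O)(=O)c2ccccn2)CC1` differs from compound 3 by 1-(isopropoxycarbonyl)piperidin-4-yl in place of 4-(methylsulfonyl)phenyl on a saturated chain carbon bound to a sulfonamide nitrogen. Within the data shown here, the one measured step at this position, a 62-fold lower number from compound 1 to compound 3 (1.79 log units; beyond the scatter), was large. Among the measured compounds shown here, compound 4 carries neither group of that step, and no step involving a 1-(isopropoxycarbonyl)piperidin-4-yl group has been measured, so the direction rests on the 4-(methylsulfonyl)phenyl group having given the far lower number in compound 3 0.2 10^-6 cm/s. Compound 4 is therefore expected to show a moderate rise, a 7.5-fold higher number from compound 3 to compound 4 (0.88 log units; beyond the scatter). The estimate for compound 4 in this assay is 1.5 10^-6 cm/s, expected to fall between 0.3 10^-6 cm/s and 7 10^-6 cm/s.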

Compound 4, apparent permeability: 1 10^-6 cm/s
Estimate against measurement, compound 4: 1.5-fold (0.18 log units) above; the measured number falls inside the stated range.
By their numbers in this assay, from the lowest: compounds 2 and 3 (each within the scatter of the next); then compound 4; then compound 1.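

In this assay the 1-(isopropoxycarbonyl)piperidin-4-yl group gives an intermediate level on the saturated chain carbon bound to a sulfonamide nitrogen, with a 5.0-fold higher number from compound 3 to compound 4 (0.70 log units; beyond the scatter) against 4-(methylsulfonyl)phenyl and a 12-fold lower number from compound 1 to compound 4 (1.09 log units; beyond the scatter) against (1H-pyrrol-1-yl)methyl. With the six-membered non-aromatic ring kept, the group on its amine nitrogen still moves the number: isopropoxycarbonyl in place of (1-methyl-1H-imidazol-4-yl)sulfonyl gives a 10-fold higher number from compound 2 to compound 4 (1.00 log units; beyond the scatter) for that change.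

As far as these compounds go, whether an acetyl group or a free amine on that ring nitrogen would approach compound 1 remains open. Nothing available explains these differences.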